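The source may hold more compounds than are shown below. What is called first, only, known or untested is meant among the compounds shown, and "the series" means these compounds.

Measured compounds:
compound 1 `CCOC(=O)c1sc(NC(=O)Cn2cc(-c3ccc(F)cc3)nn2)nc1C` — 660 nM
compound 2 `COc1ccc(-c2cn(CC(=O)Nc3cc(C)on3)nn2)cc1` — > 30000 nM
compound 3 `Cc1csc(NC(=O)Cn2cc(-c3ccc(Cl)cc3)nn2)n1` — 520 nM

All three were run in a functional assay on BMDM cells (Mus musculus, strain C57BL/6) for inhibition, with a stated time of 2 days; on this read-out higher numbers stand for weaker inhibition and lower numbers for stronger inhibition. Compound 1 gives 660 nM and compound 3 gives 520 nM; these two numbers lie within the usual scatter of each other, so neither can be set above or below the other. Compound 2 returns only a limit, > 30000 nM, and not a number. Of the two numbers shown, compound 1 has the higher one, with compound 3 as its nearest neighbour; the third entry is the limit of > 30000 nM in this assay, at which 1 of the 3 values shown sits.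

The next compound, compound 4 `CCOC(=O)c1sc(NC(=O)Cn2cc(-c3ccncc3)nn2)nc1C`, keeps the core of compound 1 and differs in one place: pyridin-4-yl in place of 4-fluorophenyl on an aromatic carbon. Going by the values given here, no measured pair in this set differs in a single place, so there is no measured step to draw on for the size of this change, and no compound here carries a pyridin-4-yl on that aromatic carbon. The expectation for compound 4 is a step of a 1.8-fold higher number from compound 1 to compound 4 (0.26 log units; within the scatter), a modest weakening that may well stay inside the scatter. Compound 4 is therefore estimated at 1200 nM, with a range from 400 nM to 4000 nM.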

Compound 4, half-maximal inhibitory concentration: 120 nM
Estimate against measurement, compound 4: 10-fold (1.00 log units) above; measured number outside the range, below it.
By their numbers in this assay, from the lowest: compound 4; then compounds 3 and 1 (each within the scatter of the next). At a limit, above all of these: compound 2.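

Going by these compounds alone, until now no measured pair differed in one place, so this is the first reading of a single change on the aromatic carbon of the five-membered aromatic ring with 3 nitrogen. In this assay, pyridin-4-yl in place of 4-fluorophenyl gives a 5.5-fold lower number from compound 1 to compound 4 (0.74 log units; beyond the scatter), so this position accepts a six-membered aromatic ring with 1 hetero atom and 1 hydrogen-bond acceptor, and inhibition grows stronger with the change. No measurement at hand speaks to which feature of the change lies behind this step.

From the compounds shown here alone, with a single step at this position, it remains open whether the gain depends on where the ring nitrogen sits, which pyridin-3-yl or pyridin-2-yl on the same carbon would test, or whether a non-aromatic group such as morpholine would serve there as well. Also open, going by these compounds, is whether the step carries over to other parts of the series, for example with a carboxylic acid or a primary amide in place of the ethyl ester on the core of compound 4.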